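Chloro for hydrogen on the phenyl of compound 3

This account rests on a few compounds, and the source may have more. Where it says the series, first, only, none or still open, it means among the compounds named here.

Measured in a functional assay on U-87MG ATCC cells for antiproliferative activity against U-87 MG (Homo sapiens), read by MTT assay, with a stated time of 48 h, tested at 5 uM; on this read-out lower numbers stand for a stronger effect and higher numbers for a weaker effect at the one concentration tested:
compound 1 `COc1ccc(-c2nc(C)c(C(=O)CSc3nc(-c4ccc(Cl)cc4)c(C#N)c(=O)[nH]3)s2)cc1` gives 102%
compound 2 `COc1ccc(-c2nc(SCC(=O)c3sc(-c4ccc(Cl)cc4)nc3C)[nH]c(=O)c2C#N)cc1OC` gives 93.4%
compound 3 `Cc1nc(-c2ccccc2)sc1C(=O)CSc1nc(-c2ccc(Cl)cc2)c(C#N)c(=O)[nH]1` gives 90.9%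

Compound 3 holds the lowest number of the three, though compound 2 lies within the scatter of it and only compound 1 lies beyond. Compound 4 `Cc1nc(-c2ccc(Cl)cc2)sc1C(=O)CSc1nc(-c2ccc(Cl)cc2)c(C#N)c(=O)[nH]1` differs from compound 3 by chloro in place of hydrogen on an aromatic carbon. Going by the values given here, the one measured step at a comparable place, a number 11.1 percentage points lower from compound 1 to compound 3 (beyond the scatter), concerns methoxy leaving, not chloro entering, and shows only that a substituent on this ring can move the read-out modestly. Among the compounds with values here, no step with chloro entering is known. For compound 4 a change of about a number 2.9 percentage points lower from compound 3 to compound 4 (within the scatter) is expected, not beyond the scatter. Compound 4 is therefore estimated at 88%, with a range from 75% to 102%.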

Compound 4, a percentage reported as activity, at one concentration (the size of the read-out at that concentration, not a potency): 99%
Compound 4: the middle estimate sits 11 percentage points below what was measured, and the stated range covers the measured number.
By their numbers in this assay, from the lowest: compounds 3, 2, 4 and 1 (each within the scatter of the next, the first and the last beyond it).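

In this assay chloro entering the phenyl gives a number 8.1 percentage points higher from compound 3 to compound 4 (within the scatter) and so cannot be told apart from hydrogen at this place. Chloro in place of methoxy gives a number 3 percentage points lower from compound 1 to compound 4 (within the scatter) as its step, and 4-chlorophenyl in place of 3,4-dimethoxyphenyl gives a number 5.6 percentage points higher from compound 2 to compound 4 (within the scatter) as its step. Chloro thus sits within the scatter of both hydrogen and methoxy, although those two lie beyond the scatter of each other. No evidence bears on these steps. As far as these compounds go, whether an amine or a carboxylic acid at this place would lower the number beyond the scatter stays open.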